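The source may report more compounds than this note shows. Statements on the series, on what has been measured and on what is new or still open speak of the compounds shown alone.

Measured compounds:
Compound 1 `O=[N+]([O-])c1ccc(O[C@H]2CCc3ccccc3[C@@H]2n2ccnn2)c(F)c1`. In an ADME assay on J774.A1 cells (Mus musculus) for cytotoxicity, read by MTT assay (a lower number here means that less compound is tolerated, a higher number that more compound is tolerated), compound 1 reports only a limit, > 100 ug/mL.
Compound 2 `O=[N+]([O-])c1cc(C(F)(F)F)ccc1O[C@H]1CCCC[C@@H]1n1ccnc1`. In this assay compound 2 gives 22.1 ug/mL.
Compound 3 `Clc1cccc(CO[C@H]2CCCC[C@@H]2n2ccnc2)c1`. In this assay compound 3 gives 12.8 ug/mL.

Compound 3 and compound 2 sit within the usual scatter of each other, so their numbers are not told apart here. Compound 1 stands at the limit (the limit of > 100 ug/mL in this assay, at which 1 of the 3 values shown sits).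

Compound 4 `Clc1ccc(Cl)c(CO[C@H]2CCCC[C@@H]2n2ccnc2)c1` differs from compound 3 in one place: chloro in place of hydrogen on an aromatic carbon. Among the compounds with values here, no measured pair shows this change, so the expectation rests on compound 3 alone. In this assay the step of a 1.6-fold lower number from compound 3 to compound 4 (0.20 log units; within the scatter) is expected to be modest, slightly toward less compound tolerated, but likely within the scatter. Compound 4 is estimated at 8 ug/mL, with a range from 3.5 ug/mL to 20 ug/mL.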

Compound 4, half-maximal cytotoxic concentration: 27.2 ug/mL
Estimate against measurement, compound 4: 3.4-fold (0.53 log units) below; the measured number lies above the stated range.
By their numbers in this assay, from the lowest: compounds 3, 2 and 4 (each within the scatter of the next, the first and the last beyond it). At a limit, above all of these: compound 1.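

In this assay, the added chloro gives a 2.1-fold higher number from compound 3 to compound 4 (0.33 log units; beyond the scatter), so this place on the ring, ortho to a large group and para to a chloro group, takes a chloro with no loss in the amount of compound tolerated. Within the data shown here, this is a single step from one pair, but no earlier pair showed any change at this place. Nothing measured here accounts for the step. As far as these compounds go, whether a fluoro, a methyl or a methoxy at this place would move the number the same way stays open. So does whether this chloro would act alike on another core, such as that of compound 1.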